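The source may hold more compounds than are shown below. What is called first, only, known or untested is meant among the compounds shown, and "the series" means these compounds.

Measured compounds:
Compound 1 `Fc1cccc2c1CC2CN1CCN(c2cccc3c2OCCO3)CC1` – 0.63 mg/kg
Compound 2 `C1=C(CCN2CCN(c3cccc4c3OCCO4)CC2)c2ccccc2C1` – 0.63 mg/kg
Compound 3 `C1=C(CCN2CCN(c3cccc4c3OCCO4)CC2)c2ccccc2CC1` – 0.63 mg/kg

All three were tested in a functional assay on the whole organism for antagonist activity, with Rattus norvegicus as the target; on this read-out higher numbers stand for an effect only at larger amounts of compound and lower numbers for an effect already at smaller amounts. On these numbers compound 1 stands level with compounds 2 and 3 at the digits given: the nearest is compound 2, with no change within the scatter, and the furthest is compound 3, again with no change within the scatter. For the measured compounds named here, no pair of measured compounds differs in only one place, so no measured step is available to guide a prediction.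

Compound 4 `Clc1cccc2c1CC2CN1CCN(c2cccc3c2OCCO3)CC1` has not been measured in this assay. It differs from compound 1 in one place:
chloro in place of fluoro on an aromatic carbon
The chloro takes the position the fluoro leaves, on an aromatic carbon of a six-membered aromatic ring of carbon only, part of a fused or bridged system of two rings.

Going by the values given here, with no measured step from which to judge a halogen exchange at this position, and with compounds 1, 2 and 3 all sitting at the same value, the step expected from compound 1 to compound 4 is no change at the digits printed from compound 1 to compound 4 (within the scatter), that is, none beyond the scatter. Compound 4 is therefore estimated at 0.63 mg/kg, with a range from 0.3 mg/kg to 1.3 mg/kg.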

Compound 4, minimum effective dose: 0.63 mg/kg
The estimate for compound 4 equals the measured number at the digits printed; the range from low to high includes it.
By their numbers in this assay, from the lowest: compounds 1, 2, 3 and 4 (each within the scatter of the next).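

In this assay, for the compounds shown here, the exchange of chloro for fluoro gives no change at the digits printed from compound 1 to compound 4 (within the scatter) as the first measured step between compounds that differ in one place, which the earlier compounds could not provide. It shows that, on this aromatic carbon of the six-membered aromatic ring of carbon only, these two halogens cannot be told apart on this read-out. The measurements at hand offer nothing that would explain why the two compounds read alike.

As far as these compounds go, the pair covers only these two halogens, so it remains open whether hydrogen, bromo, methoxy, a nitrile or an amine at the same carbon would also leave the read-out unchanged. It also leaves open whether the same exchange would read alike on another aromatic carbon of this ring.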